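Half-life at the 4-fluorocyclohexyl step

A few compounds are considered here, and "the series" means these few. Any claim that something is new, unique, unknown or untested is made for them only; others in the source may bear on it.

In an ADME assay on microsomes from liver (Homo sapiens) for metabolic stability, read by LC-MS, using NADPH, with a stated time of 45 min, tested at 3 uM (a higher number here means that the compound lasts longer, a lower number that the compound disappears faster), compound 3 `C1CCC(C(CC2CCCCN2)C2CCOCC2)CC1` gives 1.4 h. Compound 2 `Fc1ccc(C(CC2CCCCN2)C2CCCCC2)cc1` gives 1.32 h, and a 1.1-fold higher number from compound 2 to compound 3 (0.03 log units; within the scatter) places the two level within the scatter. Compound 1 `C1CCC(C(CC2CCCCN2)C2CCCC2)CC1` gives > 2.5 h, which is a limit of the assay and not a number.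

Compound 4 `FC1CCC(C(CC2CCCCN2)C2CCCCC2)CC1` carries 4-fluorocyclohexyl in place of oxan-4-yl on a saturated chain carbon bound to a saturated chain carbon and a saturated ring carbon.

Three measured steps at this place bear on the change. Both an at least 1.8-fold lower number from compound 1 to compound 2 (0.27 log units; that floor lies within the scatter) and an at least 1.7-fold lower number from compound 1 to compound 3 (0.25 log units; that floor lies within the scatter) are floors within the scatter, and a 1.1-fold higher number from compound 2 to compound 3 (0.03 log units; within the scatter) is small. No step beyond the scatter is therefore expected in this assay. The expected step is a 1.1-fold higher number from compound 3 to compound 4 (0.06 log units; within the scatter). For compound 4 the estimated half-life is 1.6 h, with an expected range of 0.9 h to 2.8 h.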

Compound 4, half-life: 1.08 h
Beside the measured number, compound 4's estimate is 1.5-fold (0.17 log units) above it; low and high end bracket the measured number.
By their numbers in this assay, from the lowest: compounds 4, 2 and 3 (each within the scatter of the next). At a limit, above all of these: compound 1.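

In this assay, 4-fluorocyclohexyl on this saturated chain carbon stands level with both oxan-4-yl and 4-fluorophenyl: a 1.3-fold lower number from compound 3 to compound 4 (0.11 log units; within the scatter) and a 1.2-fold lower number from compound 2 to compound 4 (0.09 log units; within the scatter). Going by these compounds alone, only an at least 2.3-fold lower number from compound 1 to compound 4 (0.36 log units; beyond the scatter) lies beyond the scatter, the one step at this place that does, which sets cyclopentyl apart from 4-fluorocyclohexyl. That step is a floor, since compound 1 gives a limit and not a number: the limit of > 2.5 h in this assay, at which 1 of the 4 values shown sits.

As far as these compounds go, the true distance of compound 1 from the other compounds stays open. Also open, from the compounds shown here alone, is whether the longer half-life belongs to cyclopentyl alone or extends to a group such as cyclobutyl or isopropyl at this place.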